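This account rests on a few compounds, and the source may have more. Where it says the series, first, only, none or still open, it means among the compounds named here.

Compound 1 `CC(O)(CSc1ccc(S(F)(F)(F)(F)F)cc1)C(=O)Nc1ccc(C#N)c(C(F)(F)F)c1` is measured in a functional assay on CWR22R cells (Homo sapiens) for antiproliferative activity, read by propidium iodide staining, with a stated time of 96 h (on this read-out higher numbers stand for weaker inhibition and lower numbers for stronger inhibition), at 18100 nM. Compound 2 `CC(O)(CSc1ccc(S(F)(F)(F)(F)F)cc1)C(=O)Nc1ccc([N+](=O)[O-])c(C(F)(F)F)c1` gives 9200 nM in this assay. The change between them is nitro in place of cyano on an aromatic carbon and it produced a 2.0-fold lower number from compound 1 to compound 2 (0.29 log units; within the scatter). Compound 3 `CC(O)(COc1cccc(S(F)(F)(F)(F)F)c1)C(=O)Nc1ccc(C#N)cc1C(F)(F)F` gives 11600 nM in this assay, a number close to those of compound 1 and compound 2. The difference between the core of compound 3 and the core of compound 1 is not broken down here. Compound 4 `CC(O)(COc1cccc(S(F)(F)(F)(F)F)c1)C(=O)Nc1ccc([N+](=O)[O-])cc1C(F)(F)F` remains to be measured; it differs from compound 3 by nitro in place of cyano on an aromatic carbon. This is the same kind of change as that from compound 1 to compound 2, but here the group sits meta to the trifluoromethyl group rather than ortho to it. Among the compounds with values here, an expected step of a 1.8-fold lower number from compound 3 to compound 4 (0.25 log units; within the scatter) rests on the single earlier step of a 2.0-fold lower number from compound 1 to compound 2 (0.29 log units; within the scatter), itself within the scatter, so the expectation is loose. The estimated value for compound 4 is 6500 nM, with a range from 2500 nM to 16000 nM.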

Compound 4, half-maximal inhibitory concentration: 15500 nM
Estimate against measurement, compound 4: 2.4-fold (0.38 log units) below; low and high end bracket the measured number.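

Within this assay nitro in place of cyano on an aromatic carbon gave a 1.3-fold higher number from compound 3 to compound 4 (0.13 log units; within the scatter) and, set beside the earlier step, the two results do not differ beyond the usual scatter: the same change on two cores in this assay, a 2.0-fold lower number (0.29 log units; within the scatter) from compound 1 to compound 2 and a 1.3-fold higher number (0.13 log units; within the scatter) from compound 3 to compound 4, 2.6-fold (0.42 log units) apart, within the scatter of two such steps. The change therefore gives no sign of behaving differently on the two cores. But since each step lies within the scatter, neither shows that the change has any effect on its core, so the pair cannot show that an effect carries from one core to the other.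

The compounds shown leave open whether an amine or a carboxylic acid in that place would move the number beyond the scatter. Going by these compounds, how the swap behaves on further cores also remains open.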